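The compounds below may be only part of what the source reports. "The series", "measured", "known", "first", "only" and "open" are said of these compounds alone.

Measured in a physicochemical assay for permeability, using PAMPA, with a stated time of 3 h, at pH 7.4; on this read-out lower numbers stand for lower permeability and higher numbers for higher permeability:
- compound 1 `CCOC(=O)CCNc1cc(Nc2ccc3[nH]c(=O)[nH]c3c2)c(Cl)cc1[N+](=O)[O-]`: 151 nm/s
- compound 2 `O=C(O)CCNc1cc(Nc2ccc3[nH]c(=O)[nH]c3c2)c(Cl)cc1[N+](=O)[O-]`: "impermeable" (no number reported)
- compound 3 `O=c1[nH]c2ccc(Nc3cc(NCc4cccnc4)c([N+](=O)[O-])cc3Cl)cc2[nH]1`: 147 nm/s

Among the measured compounds shown here, compound 3, at 147 nm/s, lies within the scatter of compound 1, the only other compound with a number. Compound 2 has no number to set against them.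

Next is compound 4 `O=c1[nH]c2ccc(Nc3cc(NC4CCOCC4)c([N+](=O)[O-])cc3Cl)cc2[nH]1`, not yet measured in this assay. The change is oxan-4-yl in place of (pyridin-3-yl)methyl on a nitrogen on an aromatic ring.

For the measured compounds named here, one measured step bears directly on this kind of exchange: a 1.0-fold lower number from compound 1 to compound 3 (0.01 log units; within the scatter), which lies within the scatter. It involves a different pair of groups, so the support is thin. The series also holds a warning, as compound 1 gives 151 nm/s while compound 2 is reported as "impermeable" (no number reported). Neither group in the present change carries a net charge.

No step beyond the scatter is therefore expected, and the expected step is a 1.0-fold higher number from compound 3 to compound 4 (0.01 log units; within the scatter). The estimate for compound 4 is 150 nm/s, with an expected range from 70 nm/s to 320 nm/s.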

Compound 4, apparent permeability: 101 nm/s
Estimate against measurement, compound 4: 1.5-fold (0.17 log units) above; low and high end bracket the measured number.
By their numbers in this assay, from the lowest: compounds 4, 3 and 1 (each within the scatter of the next).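

Measured in this assay, the exchange of the aromatic (pyridin-3-yl)methyl for the non-aromatic oxan-4-yl on the nitrogen gives a 1.5-fold lower number from compound 3 to compound 4 (0.16 log units; within the scatter). The comparison with the open-chain 2-(ethoxycarbonyl)ethyl group gives a 1.5-fold lower number from compound 1 to compound 4 (0.17 log units; within the scatter), so compounds 1, 3 and 4 now show three different groups at this place with no step beyond the scatter, while compound 2, reported as "impermeable" with no number, goes against any wider pattern. No measurement given here accounts for these values.

Whether the pattern extends to a chain ending in an amine remains open, as the compounds shown include none. A longer chain bearing a carboxylic acid, or an amide in place of the ester of compound 1, is equally unresolved.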